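From 2-methoxyphenyl to 3,5-dichlorophenyl in compound 4

A few compounds are considered here, and "the series" means these few. Any claim that something is new, unique, unknown or untested is made for them only; others in the source may bear on it.

In a functional assay on MCF7 cells (Homo sapiens) for cytotoxicity, read by cell counting, with a stated time of 48 h (a higher number here means a weaker inhibitor, a lower number a stronger inhibitor), compound 3 `COc1ccccc1-n1cc(COc2cccc3cnc(Nc4cccc(Cl)c4)nc23)nn1` gives 6000 nM. Compound 1 `Cc1ccc(-n2cc(COc3cccc4cnc(Nc5cccc(Cl)c5)nc34)nn2)c([N+](=O)[O-])c1` gives 4000 nM, so the two sit level, with a 1.5-fold higher number from compound 1 to compound 3 (0.18 log units; within the scatter). Compound 2 `Clc1ccc(-n2cc(COc3cccc4cnc(Nc5cccc(Cl)c5)nc34)nn2)cc1` reads > 25000 nM, which is a limit of the assay. Compound 4 `Clc1cccc(Nc2ncc3cccc(OCc4cn(-c5cc(Cl)cc(Cl)c5)nn4)c3n2)c1` differs from compound 3 by 3,5-dichlorophenyl in place of 2-methoxyphenyl on an aromatic nitrogen. The closest guide is the 4-chlorophenyl group of compound 2: the measured steps are an at least 6.2-fold higher number from compound 1 to compound 2 (0.79 log units; beyond the scatter) and an at least 4.1-fold lower number from compound 2 to compound 3 (0.61 log units; beyond the scatter). Going by the values given here, the only chlorine-bearing example thus reads weaker than both others, so a modest step towards a higher number is expected in this assay. The expected change is a 2.3-fold higher number from compound 3 to compound 4 (0.37 log units; beyond the scatter). Compound 4 is estimated at 14000 nM, within an expected range of 5000 nM to 25000 nM.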

Compound 4, half-maximal inhibitory concentration: 5000 nM
For compound 4 the middle estimate is 2.8-fold (0.45 log units) above the measured one; measured number inside the range.
By their numbers in this assay, from the lowest: compounds 1, 4 and 3 (each within the scatter of the next). At a limit, above all of these: compound 2.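

A chlorine-bearing group on this aromatic nitrogen need not read weak: in this assay 3,5-dichlorophenyl gives an at least 5.0-fold lower number from compound 2 to compound 4 (0.69 log units; beyond the scatter). It also stays level with the other two groups, with a 1.2-fold lower number from compound 3 to compound 4 (0.08 log units; within the scatter) and a 1.3-fold higher number from compound 1 to compound 4 (0.10 log units; within the scatter), so only 4-chlorophenyl stands apart here. The value of compound 2 is a limit, not a number: the limit of > 25000 nM in this assay, at which 1 of the 4 values shown sits.

Going by these compounds, it remains open whether a ring without chlorine or other substituents, or a 3-chlorophenyl group, would read like compound 4. Also open, on these data alone, is how this position would take a non-aromatic group, such as an amine on a longer chain.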